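Chain homologation on an anilide sulfonate pair

The compounds below may be only part of what the source reports. "The series", "measured", "known", "first", "only" and "open" are said of these compounds alone.

Compound 1 `CC(=O)Nc1cccc(S(=O)(=O)Oc2ccccc2C(C)C)c1` gives 31000 nM in a functional assay on M21 cells (Homo sapiens) for antiproliferative activity, read by sulforhodamine B assay, with a stated time of 48 h; a higher number here means a weaker inhibitor, a lower number a stronger inhibitor. Compound 2 `CCC(=O)Nc1cccc(S(=O)(=O)Oc2ccccc2C(C)C)c1` carries one more carbon on the amide chain; the change is methyl in place of hydrogen on a saturated chain carbon bound to a carbonyl carbon, in this assay compound 2 gives 25000 nM, and the step is a 1.2-fold lower number from compound 1 to compound 2 (0.09 log units; within the scatter). Compound 3 `CCC(=O)Nc1ccc(S(=O)(=O)Oc2ccccc2C(C)C)cc1` rests on a different core, and in this assay compound 3 gives 11000 nM, the lowest of the three numbers; the difference between the two cores is not broken down here. Compound 4 `CCCC(=O)Nc1ccc(S(=O)(=O)Oc2ccccc2C(C)C)cc1` is not yet measured. It differs from compound 3 by methyl in place of hydrogen on a saturated chain carbon, two bonds along the chain from a carbonyl carbon, the same kind of change as that from compound 1 to compound 2, but at another place: there the methyl entered on a saturated chain carbon bound to a carbonyl carbon, here it enters on a saturated chain carbon, two bonds along the chain from a carbonyl carbon. Since the earlier step stayed within the scatter, the expectation for compound 4 is a step of a 1.2-fold lower number from compound 3 to compound 4 (0.09 log units; within the scatter), resting on the measured step from compound 1 to compound 2 a 1.2-fold lower number from compound 1 to compound 2 (0.09 log units; within the scatter). Compound 4 is estimated at 9000 nM, with a likely range from 4000 nM to 20000 nM.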

Compound 4, half-maximal inhibitory concentration: 6100 nM
Estimate against measurement, compound 4: 1.5-fold (0.17 log units) above; the range from low to high includes it.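

In this assay the new step, a 1.8-fold lower number from compound 3 to compound 4 (0.26 log units; within the scatter), stays within the scatter, and it does not differ from the earlier step on the other core: the same change on two cores in this assay, a 1.2-fold lower number (0.09 log units; within the scatter) from compound 1 to compound 2 and a 1.8-fold lower number (0.26 log units; within the scatter) from compound 3 to compound 4, 1.5-fold (0.16 log units) apart, within the scatter of two such steps
On these two pairs, then, adding one methyl to the amide chain gives a similar small result on both cores, and no dependence on the core can be seen. This does not show that the added methyl lowers the number on either core, since neither step rises above the scatter, and the methyl enters at a different place along the chain in each pair, so the comparison is not one of identical positions.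

Open, on these data alone, is whether a longer chain on the amide, or a branched one such as isopropyl or tert-butyl, would move the number beyond the scatter on either core. Also open, as far as these compounds go, is what an amine or a carboxylic acid at the end of the chain would do, and whether such a change would carry from one core to the other.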